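Phenoxy for phenyl in a urea analogue at the urotensin receptor

A few compounds are considered here, and "the series" means these few. Any claim that something is new, unique, unknown or untested is made for them only; others in the source may bear on it.

Measured so far:
compound 1, `CN(C)CCC(OC(=O)Nc1ccc(-c2ccccc2)cc1)c1ccc(Cl)cc1`, 58%
compound 2, `CN(C)CCC(OC(=O)Nc1ccc(Oc2ccccc2)cc1)c1ccc(Cl)cc1`, 107%
compound 3, `CN(C)CCC(NC(=O)Nc1ccc(-c2ccccc2)cc1)c1ccc(Cl)cc1`, 91%

In an assay on NIH3T3 cells with Urotensin-2 receptor (Homo sapiens) as the target (a higher number here means a larger maximal response, a lower number a smaller maximal response), compound 1 gives 58%, while compound 2 gives 107%. The two differ in one place: phenoxy in place of phenyl on an aromatic carbon. This single change gave a number 49 percentage points higher from compound 1 to compound 2 (beyond the scatter).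

Compound 3, `CN(C)CCC(NC(=O)Nc1ccc(-c2ccccc2)cc1)c1ccc(Cl)cc1`, has a different core from compound 1; how the two cores differ is not broken down here. In this assay compound 3 gives 91%.

Compound 4, `CN(C)CCC(NC(=O)Nc1ccc(Oc2ccccc2)cc1)c1ccc(Cl)cc1`, has not yet been measured. It relates to compound 3 as compound 2 relates to compound 1: phenoxy in place of phenyl on an aromatic carbon. The place of the change is the same in both pairs, so this is the same change made on the core of compound 3.

A rise is expected for compound 4, estimated as a number 27 percentage points higher from compound 3 to compound 4 (beyond the scatter), because a number 49 percentage points higher from compound 1 to compound 2 (beyond the scatter). The expected step is somewhat smaller than the earlier one, since compound 3 already stands higher than compound 1 and a maximal response has less room to grow. Compound 4 is therefore estimated at 118%, with a likely range from 95% to 145%.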

Compound 4, largest response reached (reported as efficacy), in percent of the reference or control that the assay uses: 108%
The estimate for compound 4 lay 10 percentage points above the measured number; the measured number falls inside the stated range.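

In this assay, putting phenoxy in place of phenyl on the core of compound 3 gives a number 17 percentage points higher from compound 3 to compound 4 (beyond the scatter), so the change raises the maximal response on both cores shown. The direction of the change carries over from one core to the other, but its size does not: the same change on two cores in this assay, a number 49 percentage points higher (beyond the scatter) from compound 1 to compound 2 and a number 17 percentage points higher (beyond the scatter) from compound 3 to compound 4, 32 percentage points apart, beyond the scatter of two such steps. Among these compounds, with only two pairs, these results cannot explain why the size differs, and they cannot show that the same direction would hold on any further core.

Going by these compounds, it remains open what a methoxy or benzyloxy group would give on the same aromatic carbon, on either core. On these data alone, it is also open whether the change would keep its direction if the dimethylamine were replaced by another amine, such as piperidine, or if the chlorine were replaced by fluorine.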